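A few compounds are considered here, and "the series" means these few. Any claim that something is new, unique, unknown or untested is made for them only; others in the source may bear on it.

Of the compounds shown here, three have so far been measured in a functional assay on HEK293 cells for agonist activity at G-protein coupled receptor 39 (Homo sapiens), read by scintillation proximity assay and inositol phosphate accumulation, with a stated time of 75 min; a lower number here means that less compound is needed, a higher number that more compound is needed for the effect. Compound 1 `Cc1nn(-c2ncnc3nc[nH]c23)c2c1C(OCc1ccc(C#N)cc1)CC(=O)N2` gives 60 nM, the lowest of the two numbers recorded. Compound 3 `CCC(C(=O)NC1CC(=O)Nc2c1c(C)nn2-c1ncnc2nc[nH]c12)c1ccccc1` gives 79 nM, which lies within the usual scatter of compound 1, so the two cannot be told apart. Compound 2 `Cc1cc(C)nc(-n2nc(C)c3c2NC(=O)CC3c2ccc(F)cc2F)n1` gives only a limit of the assay, > 10000 nM. That value is the limit of > 10000 nM in this assay, at which 1 of the 3 values shown sits. Compound 4 `Cc1nn(-c2ncnc3nc[nH]c23)c2c1C(OCc1ccccc1Cl)CC(=O)N2` has not yet been measured; it differs from compound 1 in one place: 2-chlorophenyl in place of 4-cyanophenyl on a saturated chain carbon bound to an oxygen on a saturated carbon. Among the measured compounds shown here, no pair of measured compounds shows what this kind of change does, so the expected step is a moderate one, if any, towards a higher number. Compound 4 is expected to give 120 nM, within a range from 30 nM to 500 nM. The estimated step is a 2.0-fold higher number from compound 1 to compound 4 (0.30 log units; within the scatter).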

Compound 4, half-maximal effective concentration: 47 nM
Compound 4: the middle estimate sits 2.6-fold (0.41 log units) above what was measured; the measured number falls inside the stated range.
By their numbers in this assay, from the lowest: compounds 4, 1 and 3 (each within the scatter of the next). At a limit, above all of these: compound 2.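

The exchange of 4-cyanophenyl for 2-chlorophenyl on a saturated chain carbon bound to an oxygen on a saturated carbon gives a 1.3-fold lower number from compound 1 to compound 4 (0.11 log units; within the scatter) in this assay. The nitrile and its hydrogen-bond acceptor are therefore not required for a value at this level in this pair, and a chlorine serves as well. Nothing measured here explains this match. Still open, from the compounds shown here alone, is whether the aromatic ring itself is needed: an amine, a carboxylic acid or a plain longer chain in its place could give a very different number.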